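Ketone-side ring swaps in the series

The source may hold more compounds than are shown below. What is called first, only, known or untested is meant among the compounds shown, and "the series" means these compounds.

Compound 3 `COc1ccc(C(=O)/C=C/c2cc(-c3cc(OC)c(OC)c(OC)c3)n[nH]2)cc1` gives 3240 nM in a functional assay on SK-MEL-5 cells (Homo sapiens) for inhibition, read by sulforhodamine B assay, with a stated time of 48 h (a lower number here means a stronger inhibitor of growth, a higher number a weaker inhibitor of growth), and stands at the top of the three numbers, though compound 1 `COc1cc(-c2cc(/C=C/C(=O)c3ccc(N)cc3)[nH]n2)cc(OC)c1OC` at 3060 nM and compound 2 `COc1ccc(C(=O)/C=C/c2cc(-c3cc(OC)c(OC)c(OC)c3)n[nH]2)cc1OC` at 3030 nM sit close: a 1.1-fold higher number from compound 1 to compound 3 (0.02 log units; within the scatter) and a 1.1-fold higher number from compound 2 to compound 3 (0.03 log units; within the scatter) both fall within the scatter, as does a 1.0-fold lower number from compound 1 to compound 2 (0.00 log units; within the scatter). Compound 4 `COc1cc(-c2cc(/C=C/C(=O)c3ccc(F)c(F)c3)[nH]n2)cc(OC)c1OC` carries 3,4-difluorophenyl in place of 4-methoxyphenyl on a carbonyl carbon. For the measured compounds named here, every measured step so far also replaces the ring on the carbonyl carbon, and each stayed flat, so the step of a 1.0-fold lower number from compound 3 to compound 4 (0.01 log units; within the scatter) is expected to be no larger than the scatter, with no clear direction. Compound 4 is therefore estimated at 3200 nM in this assay, with a range from 1300 nM to 8000 nM.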

Compound 4, concentration for total growth inhibition: 6410 nM
For compound 4 the middle estimate is 2.0-fold (0.30 log units) below the measured one; low and high end bracket the measured number.
By their numbers in this assay, from the lowest: compounds 2, 1, 3 and 4 (each within the scatter of the next, the first and the last beyond it).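

In this assay the 3,4-difluorophenyl on the carbonyl carbon is the only ring shown to open a gap beyond the scatter, with a 2.1-fold higher number from compound 2 to compound 4 (0.33 log units; beyond the scatter) and a 2.1-fold higher number from compound 1 to compound 4 (0.32 log units; beyond the scatter) both modest, while a 2.0-fold higher number from compound 3 to compound 4 (0.30 log units; within the scatter) stays within it. This position is therefore not wholly silent to ring swaps, although the change exceeds the scatter against only two of the three earlier rings. No available measurement bears on the reason for this gap. Open, on these data alone, is how a 4-chlorophenyl or a pyridine ring on the carbonyl carbon would read here. Also open, as far as these compounds go, is whether a carboxylic acid on this ring would stay with compound 1, compound 2 and compound 3 or move further toward compound 4.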